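The source may hold more compounds than are shown below. What is called first, only, known or untested is meant among the compounds shown, and "the series" means these compounds.

Compound 1 `O=C1C=C(Nc2ccc(Cl)cc2)CCC1` gives the highest number among the three measured in an assay on isolated protein for inhibition of cytochrome c oxidase subunit 2 (Homo sapiens), read by ELISA, with a stated time of 2 min, tested at 10 uM (on this read-out higher numbers stand for more inhibition at the one concentration tested (going by the name of the read-out) and lower numbers for less inhibition), where compound 1 gives 88.6%. Compound 2 `N#Cc1ccc(NC2=CC(=O)CCC2)cc1` gives 47.1% in this assay, and compound 3 `CC(=O)c1ccc(NC2=CC(=O)CCC2)cc1` gives 41.9%. The two steps away from compound 1 are both large: a number 41.5 percentage points lower from compound 1 to compound 2 (beyond the scatter) and a number 46.7 percentage points lower from compound 1 to compound 3 (beyond the scatter). Between compounds 2 and 3 the step is a number 5.2 percentage points lower from compound 2 to compound 3 (within the scatter).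

Compound 4 `CC(C)(C)OC(=O)N(C1=CC(=O)CCC1)c1ccc(Cl)cc1` has not yet been measured in this assay. It differs from compound 1 by tert-butoxycarbonyl in place of hydrogen on a nitrogen on an aromatic ring, with the change sitting on the nitrogen that links the two parts of the shared core. Among the compounds with values here, none of the measured steps touches that nitrogen; each of them exchanges only a group on the aromatic ring. So no measured step bears directly on this change, and the expectation must stay broad. Compound 1 is expected to move by a number 38.6 percentage points lower from compound 1 to compound 4 (beyond the scatter), in the downward direction, given that every change made so far to compound 1 lowered the number, as seen in a number 41.5 percentage points lower from compound 1 to compound 2 (beyond the scatter). Compound 4 is therefore estimated at 50%, within a range from 15% to 85%.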

Compound 4, a percentage reported as inhibition, at one concentration (the size of the read-out at that concentration, not a potency): 73.5%
For compound 4 the middle estimate is 23.5 percentage points below the measured one; low and high end bracket the measured number.
By their numbers in this assay, from the lowest: compounds 3 and 2 (each within the scatter of the next); then compound 4; then compound 1.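

Within the data shown here, this is the first change at the nitrogen linking the two parts of the shared core, and it gives a number 15.1 percentage points lower from compound 1 to compound 4 (beyond the scatter) in this assay. Replacing that nitrogen's hydrogen with tert-butoxycarbonyl, which has 7 heavy atoms, thus costs some inhibition, but the step is modest, whereas the two swaps of the chloro group on the aromatic ring were both large. Nothing measured here explains why this step is smaller than those on the ring.

A single group on this nitrogen cannot show how inhibition follows the size or type of the group, so a methyl or a simple acetyl there remains an open comparison. As far as these compounds go, it is also open whether tert-butoxycarbonyl would have a similar effect with cyano or acetyl, rather than chloro, on the aromatic ring.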